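The source may hold more compounds than are shown below. What is called first, only, known or untested is meant among the compounds shown, and "the series" means these compounds.

In a functional assay on P388 cells (Mus musculus) for inhibition (a lower number here means a stronger inhibitor, a higher number a weaker inhibitor), three compounds sharing one core have been measured so far. Compound 1 `COCCOc1cc(/C=C\c2ccc3ccccc3c2)ccc1OC` gives 2990 nM, and compound 2 `Oc1ccc(/C=C/c2ccc3ccccc3c2)cc1` gives 4060 nM. Compound 3 `FC(F)(F)Oc1ccc(/C=C/c2ccc3ccccc3c2)cc1`, which carries trifluoromethoxy, gives > 5000 nM. On these data alone, that entry is a limit of the assay and not a number, so the true position of compound 3 remains open.

Compound 4 `FC(F)(F)c1ccc(/C=C/c2ccc3ccccc3c2)cc1` differs from compound 3 in one place: trifluoromethyl in place of trifluoromethoxy on an aromatic carbon. Trifluoromethyl stands in place of trifluoromethoxy on an aromatic carbon, para to a large group.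

Among the measured compounds shown here, the one measured step that bears on this change is an at least 1.2-fold higher number from compound 2 to compound 3 (0.09 log units; that floor lies within the scatter). That step offers only a floor and involves a different swap, so it gives no real size for the change ahead. No step beyond the scatter is therefore expected in this assay, and no direction can be favoured. The expected step is a number no higher from compound 3 to compound 4 (the limit leaves the size open). For compound 4, the estimated value is 5000 nM, with an expected range from 2500 nM to 10000 nM.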

Compound 4, half-maximal inhibitory concentration: > 5000 nM
Compound 4: only a limit was reported; the forecaster's own chance of this, stated with the estimate: 50%; the middle value lies on the limit itself.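

In this assay the entry for compound 4 is again a limit of the assay and not a number, so trifluoromethyl at this position, like trifluoromethoxy, yields no readable value. The change from compound 3 to compound 4 therefore has no size, and its step cannot be read, since both compounds stop at the same limit: the limit of > 5000 nM in this assay, at which 2 of the 4 values shown sit. Among the compounds shown here, the one step that can be read is an at least 1.2-fold higher number from compound 2 to compound 4 (0.09 log units; that floor lies within the scatter) and it does not separate trifluoromethyl from hydroxy.

On these data alone, how far compound 3 and compound 4 lie past the limit stays open, and so does any ranking of the two. Also open, as far as these compounds go, is whether an amine or a carboxylic acid at this position would give a number that can be compared with that of compound 2.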